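A few compounds are considered here, and "the series" means these few. Any claim that something is new, unique, unknown or untested is made for them only; others in the source may bear on it.

Compound 3 `Nc1nc(N)c(-c2ccc(CNc3ccc([N+](=O)[O-])cc3)cc2)c(COCc2ccccc2)n1` and compound 2 `CC(=O)c1ccc(CNc2ccc(-c3c(N)nc(N)nc3COCc3ccccc3)cc2)cc1` share a core that carries a (benzyloxy)methyl chain, while compound 1 `CCc1nc(N)nc(N)c1-c1ccc(NCc2ccc(C(C)=O)cc2)cc1` carries an ethyl in its place. In an in vitro assay on CHOK cells for displacement of a labelled ligand from growth hormone secretagogue receptor type 1 (Homo sapiens) (a higher number here means a weaker inhibitor, a lower number a stronger inhibitor), compound 2 gives 1.2 nM, whereas compound 1 gives 57 nM. The difference between these two is methyl in place of benzyloxy on a saturated chain carbon bound to an aromatic carbon, and it produced a 48-fold higher number from compound 2 to compound 1 (1.68 log units; beyond the scatter).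

Compound 2 and compound 3 differ elsewhere, in ((4-nitrophenyl)amino)methyl in place of (4-acetylbenzyl)amino on an aromatic carbon, and that change gave a 1.5-fold lower number from compound 2 to compound 3 (0.18 log units; within the scatter). In this assay compound 3 gives 0.8 nM.

Compound 4 `CCc1nc(N)nc(N)c1-c1ccc(CNc2ccc([N+](=O)[O-])cc2)cc1` has not yet been measured. It differs from compound 3 in methyl in place of benzyloxy on a saturated chain carbon bound to an aromatic carbon. Among the compounds with values here, the place of this change is the same as the one from compound 2 to compound 1, so it is the same change, made on the core that carries the ((4-nitrophenyl)amino)methyl group. Because the earlier instance gave a 48-fold higher number from compound 2 to compound 1 (1.68 log units; beyond the scatter), a step of similar size is expected here, namely a 48-fold higher number from compound 3 to compound 4 (1.68 log units; beyond the scatter). Starting from compound 3 with 0.8 nM, compound 4 is therefore estimated to give 38 nM in this assay, most likely between 12 nM and 120 nM.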

Compound 4, half-maximal inhibitory concentration: 9.2 nM
Estimate against measurement, compound 4: 4.1-fold (0.62 log units) above; measured number outside the range, below it.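

In this assay, methyl in place of benzyloxy on a saturated chain carbon bound to an aromatic carbon gave a 12-fold higher number from compound 3 to compound 4 (1.06 log units; beyond the scatter), so on the core with the ((4-nitrophenyl)amino)methyl group the change again raised the number by a step beyond the scatter. The direction therefore carried over between the two cores, but the size did not, and the step depended on the core it was made on: the same change on two cores in this assay, a 48-fold higher number (1.68 log units; beyond the scatter) from compound 2 to compound 1 and a 12-fold higher number (1.06 log units; beyond the scatter) from compound 3 to compound 4, 4.1-fold (0.62 log units) apart, beyond the scatter of two such steps. These two pairs do not show what sets the size of the step on either core, and they give no basis for predicting its size on a further core in this series.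

The compounds shown leave open how an amine, a carboxylic acid or a longer alkyl chain in place of benzyloxy would read in this assay. The ring and the oxygen of benzyloxy leave together in both steps, and which of them accounts for the change remains open.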